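This account rests on a few compounds, and the source may have more. Where it says the series, first, only, none or still open, it means among the compounds named here.

Measured in an ADME assay on Caco-2 cells (Homo sapiens) for permeability, read by HPLC, with a stated time of 2 h; on this read-out lower numbers stand for lower permeability and higher numbers for higher permeability:
- compound 1 `O=C1COCCN1c1ccc(C2CC(c3ccc([N+](=O)[O-])o3)=NO2)cn1`: 457 nm/s
- compound 2 `O=[N+]([O-])c1ccc(C2=NOC(c3ccc(N4CCCCC4)cc3)C2)o1`: 103 nm/s

Compound 1 stands higher of the two, and compound 2 lies below it by more than the usual scatter. Compound 3 `CN1CCN(c2ccc(C3CC(c4ccc([N+](=O)[O-])o4)=NO3)cn2)C(=O)C1` differs from compound 1 at one place: 4-methyl-2-oxopiperazin-1-yl in place of 3-oxomorpholin-4-yl on an aromatic carbon. The group changes on an aromatic carbon, and the new group keeps a six-membered non-aromatic ring. Among the compounds with values here, no measured pair shows this kind of change, so the expectation in this assay is tentative: little movement beyond the scatter, with a slight lean downward from compound 1 at 457 nm/s. The expected step is a 1.5-fold lower number from compound 1 to compound 3 (0.18 log units; within the scatter). For compound 3 the estimated value is 300 nm/s, within an expected range of 130 nm/s to 600 nm/s.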

Compound 3, apparent permeability: 333 nm/s
For compound 3 the middle estimate is 1.1-fold (0.05 log units) below the measured one; measured number inside the range.
By their numbers in this assay, from the lowest: compound 2; then compounds 3 and 1 (each within the scatter of the next).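

In this assay, 4-methyl-2-oxopiperazin-1-yl in place of 3-oxomorpholin-4-yl on this aromatic carbon gives a 1.4-fold lower number from compound 1 to compound 3 (0.14 log units; within the scatter). Within the data shown here, this is the first pair that differs at one place only, and it shows that one six-membered non-aromatic ring can replace the other here without a step beyond the scatter. Nothing available explains how close the two numbers lie. On these data alone, whether an open-chain amine or a carboxylic acid at this carbon would give a step beyond the scatter remains open. So does whether this exchange behaves alike on another core.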